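Adding ethyl to compound 3

A few compounds are considered here, and "the series" means these few. Any claim that something is new, unique, unknown or untested is made for them only; others in the source may bear on it.

In a physicochemical assay for lipophilicity, using the shake flask method, at pH 7.4 (on this read-out higher numbers stand for higher lipophilicity and lower numbers for lower lipophilicity), compound 1 `Cc1cc2c(N[C@H]3CC[C@H](N(C)C)CC3)ncnc2s1` gives 0.6, compound 2 `CN(C)[C@H]1CC[C@H](Nc2ncnc3sccc23)CC1` gives 0.1 and compound 3 `CN(C)[C@H]1CC[C@H](Nc2ncnc3[nH]ccc23)CC1` gives -0.6, the lowest of the three numbers. Compound 4 `CCc1c[nH]c2ncnc(N[C@H]3CC[C@H](N(C)C)CC3)c12` is still unmeasured. It differs from compound 3 by ethyl in place of hydrogen on an aromatic carbon. Among the compounds with values here, only one measured step bears on this, a modest one on a different core: a number 0.50 log units lower from compound 1 to compound 2 (beyond the scatter), with hydrogen in place of methyl on an aromatic carbon. Read backwards, that pair has the methyl compound higher, so a rise is expected here too, somewhat larger since ethyl is larger than methyl. The estimated change is a number 0.80 log units higher from compound 3 to compound 4 (beyond the scatter), resting on that single pair. The estimated value for compound 4 is 0.2, with an expected range from -0.2 to 0.6.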

Compound 4, distribution coefficient: 0.6
Estimate against measurement, compound 4: 0.40 log units below; measured number inside the range.
By their numbers in this assay, from the lowest: compound 3; then compound 2; then compounds 1 and 4 (each within the scatter of the next).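

In this assay, ethyl in place of hydrogen on an aromatic carbon of the five-membered aromatic ring gives a number 1.20 log units higher from compound 3 to compound 4 (beyond the scatter), a large step. Within the data shown here, the only earlier step of this kind was modest and on a different core, a number 0.50 log units lower from compound 1 to compound 2 (beyond the scatter), so this position on the core of compound 3 now has a measured step of its own. No measured evidence accounts for the size of this rise. Still open, going by these compounds, is whether a longer chain such as propyl would raise the number further at this position. An amine or a carboxylic acid there remains equally unexplored.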